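The source may hold more compounds than are shown below. What is called first, only, known or untested is meant among the compounds shown, and "the series" means these compounds.

Working notes on the series. Compound 1 `CC[C@@H]1CN(c2scnc2-c2nc3ccccc3[nH]2)CCN1C(=O)Cn1cnc2cccnc21` in an assay on blood for inhibition of C-X-C chemokine receptor type 3 (Homo sapiens), with a stated time of 30 min (on this read-out higher numbers stand for weaker inhibition and lower numbers for stronger inhibition), gives 851 nM. Compound 2 `COCCOc1ncc(-c2nc(C(F)(F)F)sc2N2CCN(C(=O)Cn3cnc4cccnc43)[C@H](C)C2)cn1` gives 182 nM in this assay, and compound 3 `CCOc1ncc(-c2nc(C(F)(F)F)sc2N2CCN(C(=O)Cn3cnc4ccccc43)[C@H](C)C2)cn1` gives 192 nM. Among the three numbers, compound 3 stands second highest; its nearest neighbour is compound 2, a gap that lies within the scatter, and its furthest is compound 1, whose higher number lies beyond the scatter. Compound 4 `CCOc1ncc(-c2nc(C(F)(F)F)sc2N2CCN(C(=O)Cn3ccc(C(F)(F)F)n3)[C@H](C)C2)cn1` is not yet measured. Relative to compound 3 it differs once: 3-(trifluoromethyl)-1H-pyrazol-1-yl in place of 1H-benzimidazol-1-yl on a saturated chain carbon bound to a carbonyl carbon. Going by the values given here, no measured pair carries this change, so its effect is unknown; the expectation is a modest step toward a weaker number, a 1.8-fold higher number from compound 3 to compound 4 (0.26 log units; within the scatter), rather than none. Compound 4 is estimated at 350 nM, within 120 nM to 1000 nM.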

Compound 4, half-maximal inhibitory concentration: 90 nM
Beside the measured number, compound 4's estimate is 3.9-fold (0.59 log units) above it; measured number below the stated range.
By their numbers in this assay, from the lowest: compound 4; then compounds 2 and 3 (each within the scatter of the next); then compound 1.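

Going by these compounds alone, at the saturated chain carbon bound to a carbonyl carbon, 1H-benzimidazol-1-yl is not required in this assay: 3-(trifluoromethyl)-1H-pyrazol-1-yl in its place gives a 2.1-fold lower number from compound 3 to compound 4 (0.33 log units; beyond the scatter) and is the first step readable. The six-membered aromatic ring of carbon only leaves with this change, and the number does not weaken. Nothing on hand accounts for the step. Going by these compounds, whether the step belongs to the trifluoromethyl or to the pyrazole ring stays open, and a methyl or a nitrile in place of the trifluoromethyl would separate the two. This single pair also leaves open whether the step would hold on another core.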